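The compounds below may be only part of what the source reports. "The series", "measured", "known", "first", "only" and "open" are said of these compounds alone.

Working notes on the series. In a functional assay on MCF7 cells (Homo sapiens) for inhibition, read by MTT assay, with a stated time of 48 h, tested at 10 uM (on this read-out lower numbers stand for less inhibition of growth and higher numbers for more inhibition of growth at the one concentration tested), compound 1 (`Cc1cc(=O)c2c(O)cc(OC/C=C/c3ccccc3)c([C@H]3CCN(C)C[C@H]3O)c2o1`) gives 7% and compound 2 (`Cc1oc2c([C@H]3CCN(C)C[C@H]3O)c(O)cc(O)c2c(=O)c1C(O)c1ccc(F)c(Br)c1`) gives 14%. These two values lie within the scatter of each other, so they set no order. Among the compounds with values here, compound 2 therefore stands level with compound 1 on the only numbers available, and both differ in more than one place, so neither value isolates a single structural change.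

Compound 3 (`Cc1oc2c([C@H]3CCN(C)C[C@H]3O)c(O)cc(O)c2c(=O)c1C(O)c1cc(F)cc(F)c1`) has not yet been measured. Its difference from compound 2 is 3,5-difluorophenyl in place of 3-bromo-4-fluorophenyl on a saturated chain carbon bound to an aromatic carbon and an oxygen on a saturated carbon. Within the data shown here, the series holds no measured step for this change, so the expectation rests on compound 2 at 14% alone.

No effect beyond the scatter is expected in this assay, and no direction can be argued with confidence. The estimated change is a number 2 percentage points lower from compound 2 to compound 3 (within the scatter). For compound 3 the expected value is 12%, with an estimated range of 2% to 25%.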

Compound 3, percent growth inhibition at one concentration: 25%
Beside the measured number, compound 3's estimate is 13 percentage points below it; the range from low to high includes it.
By their numbers in this assay, from the lowest: compounds 1 and 2 (each within the scatter of the next); then compound 3.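

The position on the saturated chain carbon bound to an aromatic carbon and an oxygen on a saturated carbon now has its first measured step: in this assay the change to 3,5-difluorophenyl from 3-bromo-4-fluorophenyl gives a number 11 percentage points higher from compound 2 to compound 3 (beyond the scatter) and counts as modest. The earlier compounds shown here could not show this, since compound 1 and compound 2 differ in more than one place, whereas here the read-out responds to the aryl group alone, with the heavy-atom count of 8 and the single six-membered aromatic ring of carbon only unchanged. Nothing at hand accounts for the step.

On these data alone, the step removes bromine and changes the fluorine pattern in one move, so it remains open which of the two carries the difference, and a single step cannot show a trend at this position. Also open, as far as these compounds go, is how an unsubstituted phenyl, a 3,5-dichlorophenyl or a pyridine ring would read at this position, and whether the result holds at concentrations other than the one tested.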